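Return to an aryl group on the five-membered ring

The compounds below may be only part of what the source reports. "The series", "measured", "known", "first", "only" and "open" are said of these compounds alone.

Of the compounds shown here, three of the shared core have been measured. Compound 1 `O=C1O[C@H]([C@@H](O)Cn2cc(-c3ccc(Br)cc3)nn2)C(OCc2ccccc2)=C1OCc1ccccc1` gives 5070 nM in a functional assay on HepG2 cells (Homo sapiens) for antiproliferative activity, read by MTT assay, with a stated time of 72 h; a lower number here means a stronger inhibitor, a higher number a weaker inhibitor. Compound 2 `O=C1O[C@H]([C@@H](O)Cn2cc(C3CC3)nn2)C(OCc2ccccc2)=C1OCc1ccccc1` gives 38100 nM in this assay, and compound 3 `O=C1O[C@H]([C@@H](O)Cn2cc(CNS(=O)(=O)c3ccc(Cl)cc3)nn2)C(OCc2ccccc2)=C1OCc1ccccc1` gives 7510 nM in this assay. Among these three numbers compound 3 holds the second highest; its nearest neighbour is compound 1, within the scatter, and its furthest is compound 2, beyond the scatter. The measured steps are a 7.5-fold higher number from compound 1 to compound 2 (0.88 log units; beyond the scatter), a 1.5-fold higher number from compound 1 to compound 3 (0.17 log units; within the scatter) and a 5.1-fold lower number from compound 2 to compound 3 (0.71 log units; beyond the scatter).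

Compound 4 `O=C1O[C@H]([C@@H](O)Cn2cc(-c3cc(F)cc(F)c3)nn2)C(OCc2ccccc2)=C1OCc1ccccc1` differs from compound 3 in one place: 3,5-difluorophenyl in place of (((4-chlorophenyl)sulfonyl)amino)methyl on an aromatic carbon. The step that bears on this is a 1.5-fold higher number from compound 1 to compound 3 (0.17 log units; within the scatter), where the 4-bromophenyl of compound 1 was exchanged for the group now leaving; it stayed within the scatter. Compound 4 takes that exchange back toward an aromatic group, so no step beyond the scatter is expected in this assay. Compound 4 is expected at 5000 nM, with a range from 2000 nM to 12000 nM. The expected step is a 1.5-fold lower number from compound 3 to compound 4 (0.18 log units; within the scatter).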

Compound 4, half-maximal inhibitory concentration: 11600 nM
For compound 4 the middle estimate is 2.3-fold (0.37 log units) below the measured one; low and high end bracket the measured number.
By their numbers in this assay, from the lowest: compounds 1, 3 and 4 (each within the scatter of the next, the first and the last beyond it); then compound 2.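

In this assay, among the compounds shown here, the exchange of 4-bromophenyl for 3,5-difluorophenyl gives a 2.3-fold higher number from compound 1 to compound 4 (0.36 log units; beyond the scatter), so this carbon of the five-membered ring distinguishes between two substituted phenyl groups, which the earlier compounds, with a single aryl group, could not show. Exchanging the (((4-chlorophenyl)sulfonyl)amino)methyl group for 3,5-difluorophenyl gives a 1.5-fold higher number from compound 3 to compound 4 (0.19 log units; within the scatter), while exchanging cyclopropyl for 3,5-difluorophenyl gives a 3.3-fold lower number from compound 2 to compound 4 (0.52 log units; beyond the scatter), so cyclopropyl remains apart from all three groups that carry a six-membered aromatic ring. Nothing available accounts for the difference between the two phenyl groups.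

Compound 1 and compound 4 differ in both the halogen and its placement on the phenyl ring, so these two effects cannot be separated. Where an unsubstituted phenyl or a carboxylic acid at this carbon would fall remains open.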